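Benzyl in place of propyl on the ring nitrogen

A few compounds are considered here, and "the series" means these few. Any claim that something is new, unique, unknown or untested is made for them only; others in the source may bear on it.

Compound 1 `CO[C@@]12CCN(Cc3ccccc3)C[C@H]1[C@H](c1ccccc1)C(C#N)=C(N)O2` gives 22600 nM in a functional assay on trachea (Cavia porcellus); on this read-out higher numbers stand for weaker inhibition and lower numbers for stronger inhibition. Within the data shown here, compound 2 `CO[C@@]12CCN(Cc3ccccc3)C[C@H]1[C@H](c1ccc(Cl)cc1)C(C#N)=C(N)O2` gives 18500 nM in this assay, and the single change between the two is a 1.2-fold lower number from compound 1 to compound 2 (0.09 log units; within the scatter). Compound 3 `CCCN1CC[C@@]2(OC)OC(N)=C(C#N)[C@@H](c3ccc(Cl)cc3Cl)[C@@H]2C1` gives 35500 nM in this assay; on the numbers shown compound 3 stands at the top of the three, yet its gap to compound 1 and its gap to compound 2 both lie within the scatter, so no order among the three can be read from these values.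

Compound 4 `CO[C@@]12CCN(Cc3ccccc3)C[C@H]1[C@H](c1ccc(Cl)cc1Cl)C(C#N)=C(N)O2` is not yet measured. Relative to compound 3 the change is phenyl in place of ethyl on a saturated chain carbon bound to an amine nitrogen in a ring, that is, propyl to benzyl. Among the measured compounds shown here, no measured pair differs at this position. For the measured compounds named here, the only measured step, a 1.2-fold lower number from compound 1 to compound 2 (0.09 log units; within the scatter), concerns chloro in place of hydrogen on an aromatic carbon and does not bear on the group on the ring nitrogen. Compounds 1 and 2 both carry the benzyl group that compound 4 would carry, and their values sit within the scatter of compound 3. On that basis no step beyond the scatter is expected in this assay. Compound 4 is expected to give 20000 nM, with a range from 8000 nM to 50000 nM. This amounts to an expected step of a 1.8-fold lower number from compound 3 to compound 4 (0.25 log units; within the scatter).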

Compound 4, half-maximal inhibitory concentration: 18300 nM
The estimate for compound 4 lay 1.1-fold (0.04 log units) above the measured number, within the range that was stated.
By their numbers in this assay, from the lowest: compounds 4, 2, 1 and 3 (each within the scatter of the next).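

Among these compounds, the pair of compound 3 and compound 4 gives the first direct reading at this position: in this assay, propyl to benzyl, that is, phenyl in place of ethyl on a saturated chain carbon bound to an amine nitrogen in a ring, gives a 1.9-fold lower number from compound 3 to compound 4 (0.29 log units; within the scatter) and so does not separate the two groups. With benzyl held constant, the aromatic substitution also stays flat: chloro in place of hydrogen on an aromatic carbon gives a 1.0-fold lower number from compound 2 to compound 4 (0.00 log units; within the scatter), and 2,4-dichlorophenyl in place of phenyl on a saturated ring carbon gives a 1.2-fold lower number from compound 1 to compound 4 (0.09 log units; within the scatter), so neither the added chloro nor the full dichloro change stands out in these four compounds.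

The reading at the amine nitrogen rests on a single pair and on only propyl and benzyl, which leaves open whether a secondary amine without a substituent, a longer chain such as hexyl, or a benzyl group carrying a carboxylic acid would move the number beyond the scatter. On these data alone, the shared core is also constant throughout, so an amide in place of the nitrile or a hydroxyl in place of the methoxy remains open as well. No measured evidence bears on these readings.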